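The source may hold more compounds than are shown below. What is called first, only, known or untested is meant among the compounds shown, and "the series" means these compounds.

Compound 3, with structure `COc1ccc(-c2c(S(=O)(=O)c3ccc(F)cc3)cnc3c(F)cccc23)cc1`, gives 2.41 mL/min in an ADME assay on microsomes from liver (Homo sapiens) for metabolic stability, tested at 2.5 uM (a lower number here means slower removal, a higher number faster removal of the compound), the highest of the three numbers recorded. Its nearest neighbour is compound 2, structure `O=S(=O)(c1ccc(F)cc1)c1cnc2c(F)cccc2c1-c1cccc(F)c1`, which gives 1.56 mL/min in this assay; the gap between these two is within the scatter. Furthest from compound 3 stands compound 1, structure `O=S(=O)(c1cc(Cl)cc(Cl)c1)c1cnc2c(F)cccc2c1-c1cccc(Cl)c1`, which gives 1.2 mL/min in this assay; this gap is also within the scatter, so the three compounds cannot be ordered with confidence.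

The step under consideration leads to compound 4, structure `O=S(=O)(c1ccc(F)cc1)c1cnc2c(F)cccc2c1-c1cccc(Cl)c1`. The structural change is 3-chlorophenyl in place of 4-methoxyphenyl on an aromatic carbon.

For the measured compounds named here, only one measured step bears on this change: a 1.5-fold higher number from compound 2 to compound 3 (0.19 log units; within the scatter), in which a 4-methoxyphenyl replaced a 3-fluorophenyl at the same position. Going from compound 3 to compound 4 reverses the first half of that move while bringing in a 3-chlorophenyl rather than a 3-fluorophenyl; compound 1 also carries a 3-chlorophenyl, though its sulfone differs. Going by the values given here, since the only relevant step was within the scatter, no step beyond the scatter is expected in this assay, with a slight leaning toward a lower number. Compound 4 is therefore estimated at 1.5 mL/min, with a range from 0.8 mL/min to 2.8 mL/min, which is expected to amount to a 1.6-fold lower number from compound 3 to compound 4 (0.21 log units; within the scatter).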

Compound 4, intrinsic clearance in a liver preparation (reported as CLH), per the amount of preparation that the assay uses: 1.21 mL/min
Compound 4: the middle estimate sits 1.2-fold (0.09 log units) above what was measured, and the stated range covers the measured number.
By their numbers in this assay, from the lowest: compounds 1, 4, 2 and 3 (each within the scatter of the next).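

In this assay, the group on this aromatic carbon, opposite the ring nitrogen, can be exchanged for 3-chlorophenyl without a step beyond the scatter: 3-chlorophenyl in place of 4-methoxyphenyl gives a 2.0-fold lower number from compound 3 to compound 4 (0.30 log units; within the scatter). The halogen on this ring can be changed on its own as well, and chloro in place of fluoro gives a 1.3-fold lower number from compound 2 to compound 4 (0.11 log units; within the scatter), so with the 4-fluorophenyl sulfone in place, the 3-fluorophenyl, 3-chlorophenyl and 4-methoxyphenyl compounds cannot be told apart with confidence. For the compounds shown here, the result also gives the first isolated reading of the group on the sulfonyl sulfur, where 4-fluorophenyl in place of 3,5-dichlorophenyl gives a 1.0-fold higher number from compound 1 to compound 4 (0.00 log units; within the scatter), so that exchange likewise shows no effect beyond the scatter in the presence of the 3-chlorophenyl group.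

No measurement shown here explains these numbers. As far as these compounds go, since all the groups at these two positions are substituted phenyl rings, it remains open whether an amine or a carboxylic acid on either ring, or a pyridine in place of either ring, would produce a step beyond the scatter.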